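Replacing phenyl with 2,4,6-trihydroxyphenyl in the benzyl series

The source may hold more compounds than are shown below. What is called first, only, known or untested is meant among the compounds shown, and "the series" means these compounds.

Of the compounds shown here, two sharing one core have numbers so far: compound 1 `Cc1cc(-c2c(F)cc3c(=O)c(Cc4ccc[nH]4)cn(C4CC4)c3c2F)cc(C)n1` and compound 2 `Cc1cc(-c2c(F)cc3c(=O)c(Cc4ccccc4)cn(C4CC4)c3c2F)cc(C)n1`. In a functional assay on P388 cells (Mus musculus) for cytotoxicity (a higher number here means a weaker inhibitor, a lower number a stronger inhibitor), compound 1 gives 930 nM with its 1H-pyrrol-2-yl group. Compound 2 gives 7300 nM with phenyl, the highest of the two numbers.

Compound 3 `Cc1cc(-c2c(F)cc3c(=O)c(Cc4c(O)cc(O)cc4O)cn(C4CC4)c3c2F)cc(C)n1` is the next to be read, and its difference from compound 2 is 2,4,6-trihydroxyphenyl in place of phenyl on a saturated chain carbon bound to an aromatic carbon in all: 2,4,6-trihydroxyphenyl in place of phenyl on a saturated chain carbon bound to an aromatic carbon.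

For the measured compounds named here, the only measured step at this place is a 7.8-fold higher number from compound 1 to compound 2 (0.89 log units; beyond the scatter) and it lies beyond the scatter, so the group here can move the number in this assay by a modest amount. Going by the values given here, no measured compound carries the 2,4,6-trihydroxyphenyl group, so that step guides the size more than the direction. Compound 2 stands at the top of the two numbers, so a modest move downward is the working expectation, and a result within the scatter remains possible.

The expected change is a 2.9-fold lower number from compound 2 to compound 3 (0.47 log units; beyond the scatter) as a rough estimate. For compound 3 the estimated value is 2500 nM with an expected range of 500 nM to 10000 nM in this assay.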

Compound 3, half-maximal inhibitory concentration: 470 nM
Compound 3: middle estimate off by 5.3-fold (0.73 log units), on the high side, and the stated range ends above it.
By their numbers in this assay, from the lowest: compounds 3 and 1 (each within the scatter of the next); then compound 2.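

In this assay, the group on the saturated chain carbon bound to an aromatic carbon can move the number much further than the earlier pair suggested: that pair gave only a modest step, a 7.8-fold higher number from compound 1 to compound 2 (0.89 log units; beyond the scatter), whereas benzyl to 2,4,6-trihydroxybenzyl gives a large one, a 16-fold lower number from compound 2 to compound 3 (1.19 log units; beyond the scatter). The two non-phenyl groups do not separate, with a 2.0-fold lower number from compound 1 to compound 3 (0.30 log units; within the scatter), so among these three compounds phenyl alone stands apart, and 1H-pyrrol-2-yl and 2,4,6-trihydroxyphenyl both sit beyond the scatter from it despite their different rings. No measurement available here bears on what lies behind this step.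

The compounds shown leave open whether the step from compound 2 to compound 3 depends on free hydroxyl groups, which 2,4,6-trimethoxyphenyl at the same place would test. They also leave open whether all the hydroxyl groups of 2,4,6-trihydroxyphenyl are needed, and whether a ring bearing an amine in their stead would read like compound 3 or like compound 2.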